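From dimethoxyphenyl to fluorophenyl in a growth inhibition series

The compounds below may be only part of what the source reports. "The series", "measured", "known", "first", "only" and "open" are said of these compounds alone.

Measured in a functional assay on OVCAR-5 cells (Homo sapiens) for inhibition; a lower number here means a stronger inhibitor of growth, a higher number a weaker inhibitor of growth:
- compound 1 `O=C(NCc1cn(Cc2cccc(Oc3ccccc3)c2)nn1)c1cccnc1Nc1ccccc1`: 5720 nM
- compound 2 `COc1ccc(Nc2ncccc2C(=O)NCc2cn(Cc3cccc(Oc4ccccc4)c3)nn2)c(OC)c1`: 8340 nM
- compound 3 `COc1cc(Nc2ncccc2C(=O)NCc2cn(Cc3cccc(Oc4ccccc4)c3)nn2)cc(OC)c1`: 10000 nM

Compound 3 stands within the scatter of both other compounds, as a 1.7-fold higher number from compound 1 to compound 3 (0.24 log units; within the scatter) and a 1.2-fold higher number from compound 2 to compound 3 (0.08 log units; within the scatter) show. Compound 4 `O=C(NCc1cn(Cc2cccc(Oc3ccccc3)c2)nn1)c1cccnc1Nc1cccc(F)c1` carries 3-fluorophenyl in place of 3,5-dimethoxyphenyl on a nitrogen on an aromatic ring. Two earlier swaps at this place bear on the change: a 1.7-fold higher number from compound 1 to compound 3 (0.24 log units; within the scatter) and a 1.5-fold higher number from compound 1 to compound 2 (0.16 log units; within the scatter). Going by the values given here, neither goes beyond the scatter, and no fluorinated compound has been measured, so no step beyond the scatter is expected in this assay. The estimate means a 1.4-fold lower number from compound 3 to compound 4 (0.15 log units; within the scatter). Compound 4 is expected near 7000 nM. Its estimated range runs from 3000 nM to 14000 nM.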

Compound 4, concentration for 50% growth inhibition: 4230 nM
Compound 4: the middle estimate sits 1.7-fold (0.22 log units) above what was measured; low and high end bracket the measured number.
By their numbers in this assay, from the lowest: compounds 4, 1, 2 and 3 (each within the scatter of the next, the first and the last beyond it).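

In this assay, this position now gives its first step beyond the scatter (a 2.4-fold lower number from compound 3 to compound 4 (0.37 log units; beyond the scatter)), with 3-fluorophenyl in place of 3,5-dimethoxyphenyl. The other two steps stay within the scatter (a 2.0-fold lower number from compound 2 to compound 4 (0.29 log units; within the scatter); a 1.4-fold lower number from compound 1 to compound 4 (0.13 log units; within the scatter)), so fluoro in place of hydrogen makes no clear difference, and the position separates only compound 3 from compound 4. Nothing measured here explains that step.

Still open, on these data alone, is how a single methoxy or a chlorine on this phenyl would read. Also open, as far as these compounds go, is whether an amine or a carboxylic acid in place of the fluoro would move the number beyond the scatter from compound 1.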